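Growth Inhibition Limits and a Larger Aniline Change

A few compounds are considered here, and "the series" means these few. Any claim that something is new, unique, unknown or untested is made for them only; others in the source may bear on it.

Values in a functional assay on OVCAR-3 cells (Homo sapiens) for antiproliferative activity, read by spectrophotometry, with a stated time of 2 days (a higher number here means a weaker inhibitor of growth, a lower number a stronger inhibitor of growth), each one a limit of the assay and not a number:
- compound 1 `Cc1cc(F)ccc1Nc1ncc(C(F)(F)F)c(N2Cc3cccc(N(C)S(C)(=O)=O)c3C2)n1`: > 30000 nM
- compound 2 `Cc1cc(Cl)ccc1Nc1ncc(C(F)(F)F)c(N2Cc3cccc(N(C)S(C)(=O)=O)c3C2)n1`: > 30000 nM
- compound 3 `Cc1ccc(Nc2ncc(C(F)(F)F)c(N3Cc4cccc(N(C)S(C)(=O)=O)c4C3)n2)c(C)c1`: > 30000 nM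

In this assay compound 3 gives > 30000 nM, which is a limit and not a number. Within the data shown here, it has no exact place, and the whole series so far is summed up as the limit of > 30000 nM in this assay, at which 3 of the 3 values shown sit.

The next compound, compound 4 `CN(c1cccc2c1CN(c1nc(Nc3ccc(Cl)c(C(F)(F)F)c3)ncc1C(F)(F)F)C2)S(C)(=O)=O`, differs from compound 3 by 4-chloro-3-(trifluoromethyl)phenyl in place of 2,4-dimethylphenyl on a nitrogen on an aromatic ring. In words, 4-chloro-3-(trifluoromethyl)phenyl stands in place of 2,4-dimethylphenyl on a nitrogen on an aromatic ring.

Among the measured compounds shown here, three measured steps bear on this change, since each swaps one group on an aromatic carbon. They are a step that the two limits leave unreadable from compound 1 to compound 2, a step that the two limits leave unreadable from compound 1 to compound 3 and a step that the two limits leave unreadable from compound 2 to compound 3. None of them has a readable size, so they offer no size or direction to carry over. The new change is also larger than any of them.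

For the measured compounds named here, with no measured step pointing either way, the expected change is a number no higher from compound 3 to compound 4 (the limit leaves the size open), with no shift beyond the scatter anticipated. For compound 4 the estimated value is 30000 nM, within an expected range from 10000 nM to 50000 nM.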

Compound 4, concentration for 50% growth inhibition: > 50000 nM
Compound 4 was reported as a limit (the forecaster's own chance of this, stated with the estimate: 70%); at least 1.6-fold (0.22 log units) between middle value and limit.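

In this assay compound 4 gives > 50000 nM, which is a limit of the assay and not a number. Among these compounds, compound 1, compound 2 and compound 3 also sit at limits, so no step from any of them to compound 4 can be read. The compounds shown leave open how strongly each inhibits growth, and whether any group in this place would give a measurable value in this assay.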